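The source may report more compounds than this note shows. Statements on the series, on what has been measured and on what is new or still open speak of the compounds shown alone.

Compound 1 `CC1CC(=O)N(CC(=O)N2CCN(c3cccc(Cl)c3)CC2)C1=O` stands level, on the numbers at hand, with compound 2 `CCC1(C)CC(=O)N(CC(=O)N2CCN(c3ccccc3C)CC2)C1=O` and compound 3 `CC1CC(=O)N(CC(=O)N2CCN(c3cccc(Cl)c3Cl)CC2)C1=O`. In a functional assay on the whole organism (strain CD1) with Mus musculus as the target, with a stated time of 0.5 h (on this read-out lower numbers stand for an effect already at smaller amounts and higher numbers for an effect only at larger amounts of compound), compound 1 gives 100 mg/kg; in this assay compound 2 gives 100 mg/kg and compound 3 gives 100 mg/kg. Compound 4 `CC1CC(=O)N(CC(=O)N2CCN(c3ccc(Cl)c(Cl)c3)CC2)C1=O` differs from compound 1 by chloro in place of hydrogen on an aromatic carbon. Among the measured compounds shown here, the one measured step that bears on this change is no change at the digits printed from compound 1 to compound 3 (within the scatter), itself a chloro in place of hydrogen on an aromatic carbon, which left the read-out where it was. The change to compound 4 is therefore expected to bring no step beyond the scatter in this assay, that is no change at the digits printed from compound 1 to compound 4 (within the scatter). Compound 4 is thus expected to give 100 mg/kg in this assay, with a range from 50 mg/kg to 200 mg/kg.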

Compound 4, minimum effective dose: 100 mg/kg
Compound 4: the middle estimate sits on the measured number at the digits printed, within the range that was stated.
By their numbers in this assay, from the lowest: compounds 1, 2, 3 and 4 (each within the scatter of the next).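

In this assay, chloro at the position para to a large group, ortho to a chloro group, gives no change at the digits printed from compound 1 to compound 4 (within the scatter) on the 3-chlorophenyl compound, so this position tolerates chloro on this read-out. The swap to 3,4-dichlorophenyl in place of 2,3-dichlorophenyl gives no change at the digits printed from compound 3 to compound 4 (within the scatter) and so separates neither chlorine pattern from the other. No evidence at hand explains this flat picture.

Going by these compounds, whether methoxy or an amine at this same position would move the read-out remains open. So does whether any group here could bring the effect to smaller amounts.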